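The source may hold more compounds than are shown below. What is called first, only, known or untested is meant among the compounds shown, and "the series" means these compounds.

Measured compounds:
compound 1, `Cc1cc(C)c(CN2CCc3c(Cl)cc([C@H](CO)[C@@H]4CCCO4)c(Cl)c3C2=O)c(=O)[nH]1`, 10 nM
compound 2, `COC(c1cc(Cl)c2c(c1Cl)C(=O)N(Cc1c(C)cc(C)[nH]c1=O)CC2)C1CCOC1`, 130 nM; 30 nM; 1.9 nM; 0.6 nM (4 entries)
compound 3, `COC(c1cc(Cl)c2c(c1Cl)C(=O)N(Cc1c(C)cc(C)[nH]c1=O)CC2)C1CCS(=O)(=O)CC1`, 93 nM; 0.35 nM (2 entries)

The read-out throughout is an assay for inhibition of histone-lysine N-methyltransferase EZH2 variant Y641N (Homo sapiens), read by scintillation counting, with a stated time of 60 min, in the presence of a further agent that is not named here; on this read-out lower numbers stand for stronger inhibition and higher numbers for weaker inhibition. Compound 1, `Cc1cc(C)c(CN2CCc3c(Cl)cc([C@H](CO)[C@@H]4CCCO4)c(Cl)c3C2=O)c(=O)[nH]1`, is the only one of the three with a single number, 10 nM. Compound 2 and compound 3 each appear repeatedly, with widely spread values: compound 2 gives 130 nM; 30 nM; 1.9 nM; 0.6 nM (4 entries) and compound 3 gives 93 nM; 0.35 nM (2 entries). These spreads are far wider than the usual scatter of this assay, and both compounds are drawn without a fixed configuration, so the separate entries most likely stand for different spatial arrangements of the same atoms; see the several entries of compound 2 in this assay, 130 nM; 30 nM; 1.9 nM; 0.6 nM (4 entries) and (the several entries of compound 3 in this assay, 93 nM; 0.35 nM (2 entries)).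

Compound 4, `Cc1cc(C)c(CN2CCc3c(Cl)cc([C@H](CO)[C@H]4CCCO4)c(Cl)c3C2=O)c(=O)[nH]1`, is not yet measured. Compared with compound 1 it changes as follows: the two compounds have the same atoms and bonds and differ only in configuration as drawn: 1 of 2 stereo elements differ; a stereocentre at a saturated ring carbon is drawn S in compound 1 and R in compound 4. For the measured compounds named here, no measured pair differing only in configuration is available, but the spread within compound 2 and within compound 3 shows that such arrangements can move this read-out well beyond the scatter, in either direction. For compound 4 a step of a 2.5-fold higher number from compound 1 to compound 4 (0.40 log units; beyond the scatter) is therefore expected, with real uncertainty about the direction. Compound 4 is estimated at 25 nM, within a range from 1.5 nM to 300 nM.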

Compound 4, inhibition constant: 8 nM
Compound 4: middle estimate off by 3.1-fold (0.49 log units), on the high side; the range from low to high includes it.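

In this assay, the one stereocentre at a saturated ring carbon that differs gives a 1.3-fold lower number from compound 1 to compound 4 (0.10 log units; within the scatter). This is the first pair here in which a single change of configuration can be read directly, and the result can be tied to that one stereocentre alone, since nothing else in the two structures changes: the fact that compounds 1 and 4 differ only in the configuration as drawn The very wide spreads seen earlier therefore do not apply to every stereocentre in this series, and at this ring carbon the two drawn arrangements cannot be told apart by this read-out, unlike the separate entries of compound 2: the several entries of compound 2 in this assay, 130 nM; 30 nM; 1.9 nM; 0.6 nM (4 entries)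

As far as these compounds go, the second stereo element is drawn alike in compound 1 and compound 4, so what inverting it would do remains open, and the entries of compound 2 and compound 3 cannot be assigned to particular arrangements. From the compounds shown here alone, it is also open whether this stereocentre would stay just as unimportant in a compound carrying an amine or a carboxylic acid.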